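Chloro for Fluoro on a Fused Ring: One Halogen Swap

The compounds below may be only part of what the source reports. "The series", "measured", "known", "first", "only" and "open" are said of these compounds alone.

Measured compounds:
Compound 1, `O=C(Nc1ccccc1)Nc1nc2ccc(F)cc2s1`: > 10 ug/mL
Compound 2, `O=C(Nc1cccc([N+](=O)[O-])c1)Nc1nc2ccc(F)cc2s1`: 1.96 ug/mL
Compound 3, `Cc1cc(C)c2sc(NC(=O)c3ccc([N+](=O)[O-])cc3)nc2c1`: 1.74 ug/mL

Three compounds share a fused bicyclic core. In a functional assay on SK-HEP1 cells (Homo sapiens) for antiproliferative activity, read by sulforhodamine B assay (a higher number here means a weaker inhibitor of growth, a lower number a stronger inhibitor of growth), compound 1 gives only a limit of the assay, > 10 ug/mL. Compound 2 gives 1.96 ug/mL in this assay, and compound 3 gives 1.74 ug/mL; these two numbers lie within the scatter of each other, so neither can be placed ahead of the other. Among the compounds with values here, the single step that is known, an at least 5.1-fold lower number from compound 1 to compound 2 (0.70 log units; beyond the scatter), rests on a limit, (the limit of > 10 ug/mL in this assay, at which 1 of the 3 values shown sits), and concerns a nitro group rather than a halogen.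

Compound 4, `O=C(Nc1cccc([N+](=O)[O-])c1)Nc1nc2ccc(Cl)cc2s1`, differs from compound 2 in one place: chloro in place of fluoro on an aromatic carbon. Within the data shown here, no measured step touches a change of this kind, and no pair among the three measured compounds isolates it. The expectation therefore defaults to a step of no size beyond the scatter, a 1.1-fold lower number from compound 2 to compound 4 (0.04 log units; within the scatter). Compound 4 is expected to give about 1.8 ug/mL in this assay, with a plausible range from 0.7 ug/mL to 5 ug/mL.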

Compound 4, concentration for 50% growth inhibition: 2.21 ug/mL
Estimate against measurement, compound 4: 1.2-fold (0.09 log units) below; the measured number falls inside the stated range.
By their numbers in this assay, from the lowest: compounds 3, 2 and 4 (each within the scatter of the next). At a limit, above all of these: compound 1.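

The step for chloro in place of fluoro on this aromatic carbon of the six-membered ring, a 1.1-fold higher number from compound 2 to compound 4 (0.05 log units; within the scatter), gives this assay its first reading of a change at this position. The two halogens cannot be told apart here: with the nitro group in place, compound 2 and compound 4 read alike, and swapping fluoro for chloro costs nothing that can be read. Nothing measured among these compounds offers a reason for this result.

As far as these compounds go, what bromo, methoxy or an amine would do on this same aromatic carbon remains open. So does the question of whether the two halogens would also read alike without the nitro group, as in compound 1, whose > 10 ug/mL is a limit of the assay and not a number.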